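Swapping one aryl ring on a shared core: an estimate

This account rests on a few compounds, and the source may have more. Where it says the series, first, only, none or still open, it means among the compounds named here.

Compound 1, `COc1ccc(C2=C(c3cc(OC)c(OC)c(OC)c3)C(=O)CC2C)cc1C(=O)O`, gives > 100 ug/mL in an ADME assay on MIA PaCa-2 cells (Homo sapiens) for cytotoxicity, read by MTT assay, with a stated time of 72 h (a higher number here means a weaker inhibitor, a lower number a stronger inhibitor), which is a limit of the assay rather than a number.
Compound 2, `COc1ccc(OC)c(C2=C(c3cc(OC)c(OC)c(OC)c3)C(=O)CC2O[SiH2]C(C)(C)C)c1`, gives > 100 ug/mL in this assay, again a limit.
Compound 3, `COc1ccc(OC)c(C2=C(c3cc(OC)c(OC)c(OC)c3)C(=O)CC2O)c1`, gives > 100 ug/mL in this assay, also a limit.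

Compound 2 therefore stands only at the limit, as the limit of > 100 ug/mL in this assay, at which 3 of the 3 values shown sit, shows for every value in hand. Going by the values given here, the one step between these compounds, a step that the two limits leave unreadable from compound 2 to compound 3, cannot be read, because both ends are limits. Compound 4, `COc1ccc(C2=C(c3cc(OC)c(OC)c(OC)c3)C(=O)CC2O[SiH2]C(C)(C)C)cc1`, differs from compound 2 by 4-methoxyphenyl in place of 2,5-dimethoxyphenyl on a double-bonded ring carbon. Among the compounds with values here, no measured step touches that change, so nothing points to a shift beyond the scatter. Compound 4 is therefore expected to sit near the limit as well, estimated at 150 ug/mL, within 50 ug/mL to 400 ug/mL, with the expected step being a step that the limit leaves unreadable from compound 2 to compound 4.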

Compound 4, half-maximal inhibitory concentration: > 100 ug/mL
Compound 4: a limit, no number; the forecaster's own chance of this, stated with the estimate: 75%; the middle value does not contradict the limit.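

Compound 2 and compound 4 each give only a limit of the assay, not a number, so the step between them cannot be read. The compounds shown leave open whether any change on the shared core gives a readable value in this assay.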